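Taking Away the Terminal Diol of Compound 2

A few compounds are considered here, and "the series" means these few. Any claim that something is new, unique, unknown or untested is made for them only; others in the source may bear on it.

Three polyacetylenes have been tested in a functional assay on the whole organism with Amphibalanus amphitrite as the target; a higher number here means that more compound is needed for the effect, a lower number that less compound is needed. Compound 1 `C#C/C=C\CCCC/C=C\C#CC#CC(O)CCC#CC#CC(O)CO` gives 1.3 ug/mL, compound 2 `C#C/C=C\CCCC/C=C\C#CC#CCCCC#CC#C[C@@H](O)CO` gives 0.25 ug/mL, and compound 3 `C#C/C=C/C(O)CCC/C=C\C#CC#CCCCC#CC#CC(O)CO` gives 1.3 ug/mL. Compound 2 thus has the lowest number of the three, and its gaps to compound 1 and to compound 3 both lie beyond the scatter. Compound 4 `C#CC#CCCCC#CC#C/C=C\CCCC/C=C\C#C` has not yet been measured. It differs from compound 2 by hydrogen in place of 1,2-dihydroxyethyl on a triple-bonded carbon. Among the compounds with values here, no measured pair shows this change, so the direction of the step from compound 2 to compound 4 is not known from the data. Nonetheless compound 4 is expected to need more compound than compound 2, a step of a 4.0-fold higher number from compound 2 to compound 4 (0.60 log units; beyond the scatter) being estimated, with a value of 1 ug/mL in the range from 0.25 ug/mL to 4 ug/mL.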

Compound 4, concentration for half-maximal effect: 0.25 ug/mL
For compound 4 the middle estimate is 4.0-fold (0.60 log units) above the measured one; the measured number falls inside the stated range.
By their numbers in this assay, from the lowest: compounds 2 and 4 (each within the scatter of the next); then compounds 1 and 3 (each within the scatter of the next).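

In this assay, hydrogen in place of 1,2-dihydroxyethyl on a triple-bonded carbon gives no change at the digits printed from compound 2 to compound 4 (within the scatter). Within the data shown here, the low number of compound 2 therefore does not depend on the 1,2-dihydroxyethyl group or its defined stereocentre, a point the earlier compounds, which all carry that group, could not show. Nothing at hand explains this result. From the compounds shown here alone, whether a carboxylic acid, an amine or a longer chain on that carbon would also leave the number in place remains open.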